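Amino in place of hydrogen on compound 3

The compounds below may be only part of what the source reports. "The series", "measured", "known", "first", "only" and "open" are said of these compounds alone.

In a physicochemical assay for metabolic stability, read by HPLC, at pH 4.5, tested at 10 uM (a higher number here means that the compound lasts longer, a lower number that the compound disappears faster), compound 1 `COc1nc2ccccc2n1C(=O)NCCCCc1ccccc1` gives > 2 h, which is a limit and not a number. Compound 2 `O=C(NCCCCc1ccccc1)n1ncc2ccccc21` gives > 2 h, also a limit. Within the data shown here, compound 3 `Cc1ccccc1CNC(=O)n1cnc2ccccc21` gives 1.37 h, the only actual number in the set, so it is the only firm reference point for what follows.

Compound 4 `Cc1ccccc1CNC(=O)n1c(N)nc2ccccc21` keeps the frame of compound 3 and has amino in place of hydrogen on an aromatic carbon. The new group sits on a five-membered aromatic ring with 2 nitrogen, between two ring nitrogen atoms, and next to the ring atom that bears a large group.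

Among the measured compounds shown here, no two measured compounds differ in one place only, so the set offers no direct measure of step size. The expected change a 1.2-fold higher number from compound 3 to compound 4 (0.09 log units; within the scatter) is small and upward, and is not expected to go beyond the scatter in this assay. This expectation starts from compound 3 at 1.37 h. For compound 4 the estimated half-life is 1.7 h, with an expected range of 0.8 h to 3.5 h.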

Compound 4, half-life: 0.45 h
Compound 4: middle estimate off by 3.8-fold (0.58 log units), on the high side, and the stated range ends above it.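

In this assay, among these compounds, amino in place of hydrogen on an aromatic carbon gives a 3.0-fold lower number from compound 3 to compound 4 (0.48 log units; beyond the scatter), the first step that can be read. This place, on a five-membered aromatic ring with 2 nitrogen and between two ring nitrogen atoms, is therefore not indifferent to substitution: 1 heavy atom entering there is enough to carry the half-life beyond the scatter. Nothing shown gives a reason for the direction of this step.

Methyl or a dimethylamino group on the same carbon, on the frame of compound 3, would show whether the drop is particular to amino. Compound 1 and compound 2 differ from compound 3 in more than one place and are known only as a limit of the assay, so they give no further comparison: the limit of > 2 h in this assay, at which 2 of the 4 values shown sit.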